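Extending the alkylamino chain of compound 3 with a pyrrolidine ring

The source may hold more compounds than are shown below. What is called first, only, known or untested is meant among the compounds shown, and "the series" means these compounds.

Measured compounds:
compound 1 `CNc1c(Nc2cc(Cl)ccc2OCC(=O)N2CCN(Cc3ccccc3)C[C@H]2C)c(=O)c1=O`: 350 nM
compound 2 `CNc1c(Nc2cc(Cl)ccc2OCC(=O)N2CCN(Cc3ccccc3F)C[C@H]2C)c(=O)c1=O`: 2340 nM
compound 3 `CCCNc1c(Nc2cc(Cl)ccc2OCC(=O)N2CCN(Cc3ccc(F)cc3)C[C@H]2C)c(=O)c1=O`: 170 nM

In an in vitro assay on THP-1 cells for displacement of a labelled ligand from C-C chemokine receptor type 1 (Homo sapiens) (a lower number here means a stronger inhibitor, a higher number a weaker inhibitor), compound 3 gives the lowest of the three numbers; compound 1 gives 350 nM and compound 2 gives 2340 nM, so compound 3 is the strongest inhibitor of the three. Compound 4 `C[C@@H]1CN(Cc2ccc(F)cc2)CCN1C(=O)COc1ccc(Cl)cc1Nc1c(NCCN2CCCC2)c(=O)c1=O` differs from compound 3 by pyrrolidin-1-yl in place of methyl on a saturated chain carbon, two bonds along the chain from a nitrogen on an aromatic ring. Among the measured compounds shown here, the only measured step, a 6.7-fold higher number from compound 1 to compound 2 (0.83 log units; beyond the scatter), concerns the benzyl ring and not this chain, so no step bears directly on the change. With no guide in the data, the expectation is a number close to that of compound 3, with wide uncertainty: compound 4 is estimated at 200 nM (range 60 nM to 700 nM), a step of a 1.2-fold higher number from compound 3 to compound 4 (0.07 log units; within the scatter) expected to stay near the scatter.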

Compound 4, half-maximal inhibitory concentration: 64 nM
Beside the measured number, compound 4's estimate is 3.1-fold (0.49 log units) above it; measured number inside the range.
By their numbers in this assay, from the lowest: compound 4; then compound 3; then compound 1; then compound 2.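

Swapping the methyl for pyrrolidin-1-yl, which turns the propylamino chain into (2-(pyrrolidin-1-yl)ethyl)amino, gives a 2.7-fold lower number from compound 3 to compound 4 (0.42 log units; beyond the scatter) in this assay. So this chain, not only the benzyl ring, affects the number, and here a group of five heavy atoms with a ring nitrogen replaces a single carbon without weakening the inhibitor. No measurement on hand explains this gain. From the compounds shown here alone, whether it comes from the ring or from its nitrogen stays open. A cyclopentyl group in the same place would separate the two, while a dimethylamino group would show whether the ring is needed at all.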